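The source may hold more compounds than are shown below. What is called first, only, known or untested is meant among the compounds shown, and "the series" means these compounds.

In a functional assay on the whole organism (stomach) for inhibition, with Rattus norvegicus as the target, at a dose of 100 mg/kg by the intraduodenal route (on this read-out higher numbers stand for more inhibition at the one dose given (going by the name of the read-out) and lower numbers for less inhibition), compound 3 `N=C(S)CCCCN1N=C(c2ccccc2)CCC1=O` gives 50.2%, the second highest of the three numbers; compound 1 `N=C(S)CCCCCCN1N=C(c2ccccc2)CCC1=O` gives 68.3%, and compound 2 `CC(CC(=N)S)n1nc(-c2ccccc2)ccc1=O` gives 15.5%. Compound 4 `N=C(S)CCCN1N=C(c2ccccc2)CCC1=O` differs from compound 3 by a group of 3 heavy atoms (1 carbon, 1 nitrogen, 1 sulfur; no ring) in place of a group of 4 heavy atoms (2 carbon, 1 nitrogen, 1 sulfur; no ring), on a saturated chain carbon, three bonds along the chain from an amide-type nitrogen in a ring. Among the measured compounds shown here, the one step that bears on this change is a number 18.1 percentage points lower from compound 1 to compound 3 (beyond the scatter), a replacement of the same kind at a saturated chain carbon. A step of similar direction is therefore expected here, lower beyond the scatter, which means an expected step of a number 15.2 percentage points lower from compound 3 to compound 4 (beyond the scatter). Compound 2 shows the lowest number among the three but differs from compound 4 in more than one place, so it only loosely supports the expected direction. Compound 4 is thus estimated at 35% in this assay, with a range from 15% to 55%.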

Compound 4, a percentage reported as inhibition, in the whole organism at one dose (the size of the read-out at that dose, not a potency): 50.3%
Beside the measured number, compound 4's estimate is 15.3 percentage points below it, and the stated range covers the measured number.
By their numbers in this assay, from the lowest: compound 2; then compounds 3 and 4 (each within the scatter of the next); then compound 1.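

In this assay, the group of 3 heavy atoms in place of the group of 4 heavy atoms shows a number 0.1 percentage points higher from compound 3 to compound 4 (within the scatter), so compound 3 and compound 4 cannot be told apart at this saturated chain carbon. The longer chain still counts, with a number 18 percentage points lower from compound 1 to compound 4 (beyond the scatter), so the number does not fall evenly with each shortening across these compounds. Nothing measured here explains this.

Still open, on these data alone, is whether a shorter chain, or one longer than in compound 1, would hold the number. An amine or carboxylic acid in place of the end group also remains untested in the compounds shown.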